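From compound 2 to compound 4: chloro removal

A few compounds are considered here, and "the series" means these few. Any claim that something is new, unique, unknown or untested is made for them only; others in the source may bear on it.

Values in a functional assay on MDA-MB-231 cells (Homo sapiens) for cytotoxicity, read by MTT assay, with a stated time of 72 h; a higher number here means a weaker inhibitor, a lower number a stronger inhibitor:
- compound 1 `CCN(CC)Cc1ccc2nc(NC(=O)N/N=C/c3cn(Cc4ccc(Cl)cc4Cl)c4ccccc34)sc2c1`: 3280 nM
- compound 2 `CCN(CC)Cc1ccc2nc(NC(=O)N/N=C/c3cn(Cc4ccc(Cl)cc4)c4ccccc34)sc2c1`: 2570 nM
- compound 3 `CN(C)Cc1ccc2nc(NC(=O)N/N=C/c3cn(Cc4ccc(Cl)cc4)c4ccccc34)sc2c1`: 880 nM

Compound 2 stands within the scatter of compound 1, and the only step beyond the scatter among these numbers is a 2.9-fold lower number from compound 2 to compound 3 (0.47 log units; beyond the scatter). That step exchanges diethylamino for dimethylamino and does not bear on the change considered here. Compound 4 `CCN(CC)Cc1ccc2nc(NC(=O)N/N=C/c3cn(Cc4ccccc4)c4ccccc34)sc2c1` has not been measured. Its difference from compound 2 is hydrogen in place of chloro on an aromatic carbon, that is, 4-chlorobenzyl to benzyl. Among the measured compounds shown here, the one measured step of the same kind, hydrogen in place of chloro on an aromatic carbon, is a 1.3-fold lower number from compound 1 to compound 2 (0.11 log units; within the scatter), so no step beyond the scatter is expected in this assay. The estimated step is a 1.1-fold higher number from compound 2 to compound 4 (0.02 log units; within the scatter). For compound 4 the estimated value is 2700 nM, with an expected range of 1300 nM to 5400 nM.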

Compound 4, half-maximal inhibitory concentration: 1470 nM
For compound 4 the middle estimate is 1.8-fold (0.26 log units) above the measured one; measured number inside the range.
By their numbers in this assay, from the lowest: compounds 3, 4, 2 and 1 (each within the scatter of the next, the first and the last beyond it).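

In this assay taking the chloro off the 4-chlorobenzyl group gives a 1.7-fold lower number from compound 2 to compound 4 (0.24 log units; within the scatter) and so matches the step that removed the other chloro in staying within the scatter. Taking both chloro groups together gives a 2.2-fold lower number from compound 1 to compound 4 (0.35 log units; beyond the scatter) and this is the only change on the benzyl group shown that lies beyond the scatter, though modestly. Still open, on these data alone, is whether methoxy or an amine on that aromatic carbon would shift the number away from that of compound 4, and whether dimethylamino in place of diethylamino carries over to the benzyl compound. Nothing at hand accounts for these steps.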